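Trimethoxybenzoyl Hydrazones: From Difluorophenyl to Dichlorophenyl

The compounds below may be only part of what the source reports. "The series", "measured", "known", "first", "only" and "open" are said of these compounds alone.

This account concerns three measured compounds and one that awaits measurement. In a functional assay on BGC-823 cells (Homo sapiens) for antiproliferative activity, read by MTT assay, tested at 5 uM (a lower number here means a weaker effect, a higher number a stronger effect of the compound at the concentration tested), compound 1, with structure `COc1cc(C(=O)N/N=C/c2ccc(F)c(F)c2)cc(OC)c1OC`, gives 51.9%, the highest of the three numbers in hand. Compound 3, built as `COc1ccc(OC)c(C2OC(c3cc(OC)c(OC)c(OC)c3)=NN2C(C)=O)c1`, gives 18.2% in this assay, which lies well below compound 1, beyond the usual scatter. Compound 2, with structure `COc1ccc(/C=N/NC(=O)c2cc(OC)c(OC)c(OC)c2)c(OC)c1`, gives 3.6% in this assay, the lowest number and again beyond the scatter from compound 1.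

Compound 4, with structure `COc1cc(C(=O)N/N=C/c2c(Cl)cccc2Cl)cc(OC)c1OC`, is reached from compound 1 by a single change: 2,6-dichlorophenyl in place of 3,4-difluorophenyl on a carbon with a double bond to nitrogen. Going by the values given here, no measured pair shows this kind of change, so its size cannot be read from the data. The author expects the step of a number 16.9 percentage points lower from compound 1 to compound 4 (beyond the scatter) to be a moderate loss, likely beyond the scatter, although a result within the scatter of compound 1 remains plausible. For compound 4 the estimate in this assay is 35%, with a range from 12% to 58%.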

Compound 4, a percentage reported as inhibition, at one concentration (the size of the read-out at that concentration, not a potency): 27.8%
Estimate against measurement, compound 4: 7.2 percentage points above, within the range that was stated.
By their numbers in this assay, from the lowest: compound 2; then compounds 3 and 4 (each within the scatter of the next); then compound 1.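

Going by these compounds alone, compound 1 and compound 4 form the first one-place comparison, and it gives this position a direct reading in this assay: a number 24.1 percentage points lower from compound 1 to compound 4 (beyond the scatter). The 3,4-difluorophenyl and 2,6-dichlorophenyl groups have the same counts of heavy atoms, hydrogen-bond donors and hydrogen-bond acceptors, and neither carries a net charge, so this step appears with those counts unchanged. Nothing available explains the loss.

The compounds shown leave open whether the step follows the kind of halogen or the places it occupies on the ring, as the two change together here. They also leave open how the same carbon with a double bond to nitrogen would fare with a phenyl ring carrying an amine or a carboxylic acid.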